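Two Fluorophenyl Isomers and a Cytotoxicity Limit

The source may report more compounds than this note shows. Statements on the series, on what has been measured and on what is new or still open speak of the compounds shown alone.

Compound 1 `O=C(N/N=C/N1CCN(c2cc3c(cc2F)c(=O)c(C(=O)O)cn3C2CC2)CC1)c1cccc(F)c1` and compound 2 `CCn1cc(C(=O)O)c(=O)c2cc(F)c(N3CCN(/C=N/NC(=O)c4ccc(F)cc4)CC3)cc21` were both examined in an ADME assay on HepG2 cells (Homo sapiens) for cytotoxicity, read by MTT assay; on this read-out higher numbers stand for weaker inhibition and lower numbers for stronger inhibition. For compound 1 the assay reports only a limit, > 812000 nM. For compound 2 it likewise reports only a limit, > 797000 nM, so compound 2 stands at the limit of > 797000 nM in this assay, at which 1 of the 2 values shown sits, rather than at a number. Compound 3 `CCn1cc(C(=O)O)c(=O)c2cc(F)c(N3CCN(/C=N/NC(=O)c4cccc(F)c4)CC3)cc21` carries 3-fluorophenyl in place of 4-fluorophenyl on a carbonyl carbon. Among the measured compounds shown here, no measured step joins the two. In this assay the expected step is a step that the limit leaves unreadable from compound 2 to compound 3, nothing beyond the scatter. Compound 3 is therefore estimated at 800000 nM, with a range from 300000 nM to 2000000 nM, and will most likely again be reported only as a limit.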

Compound 3, half-maximal inhibitory concentration: > 393000 nM
Compound 3 was reported as a limit (the forecaster's own chance of this, stated with the estimate: 85%); the middle value does not contradict the limit.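

Among the compounds shown here, compound 1, compound 2 and compound 3 are all reported only as limits in this assay, so no step among them can be read. The compounds shown leave open how much 3-fluorophenyl and 4-fluorophenyl, or ethyl and cyclopropyl, differ in this assay.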